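The source may report more compounds than this note shows. Statements on the series, on what has been measured and on what is new or still open speak of the compounds shown alone.

Compound 3 `COc1ccc(/C=C\C(=O)O)c(OCc2cn(-c3cccnc3Cl)nn2)c1CC=C(C)C` belongs to a small set of close relatives that share one core and differ only in the group carried on an aromatic nitrogen. In a functional assay on HCT-116 cells (Homo sapiens) for cytotoxicity, read by MTT assay, with a stated time of 24 h (on this read-out lower numbers stand for stronger inhibition and higher numbers for weaker inhibition), compound 3 gives 23000 nM, the lowest of the two numbers available. Compound 2 `COc1ccc(/C=C\C(=O)O)c(OCc2cn(-c3ccccc3)nn2)c1CC=C(C)C` gives 26000 nM in this assay. The step of a 1.1-fold lower number from compound 2 to compound 3 (0.05 log units; within the scatter) stays within the scatter, so the two cannot be ranked. For compound 1 `COc1ccc(/C=C\C(=O)O)c(OCc2cn(-c3ccc(NC(C)=O)cc3)nn2)c1CC=C(C)C` the entry in this assay reads "not determined" (no result reported), so no number is available for it. Compound 4 `COc1ccc(/C=C\C(=O)O)c(OCc2cn(-c3cccc([N+](=O)[O-])c3)nn2)c1CC=C(C)C` differs from compound 3 by 3-nitrophenyl in place of 2-chloropyridin-3-yl on an aromatic nitrogen. Going by the values given here, the only measured step of the same kind, at the same place, produced no change beyond the scatter. For compound 4 the expected step is therefore a 1.0-fold higher number from compound 3 to compound 4 (0.02 log units; within the scatter). Compound 4 is estimated at 24000 nM in this assay, within a range from 10000 nM to 60000 nM.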

Compound 4, half-maximal inhibitory concentration: 27300 nM
Compound 4: the middle estimate sits 1.1-fold (0.06 log units) below what was measured, and the stated range covers the measured number.
By their numbers in this assay, from the lowest: compounds 3, 2 and 4 (each within the scatter of the next).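

In this assay, replacing one ring on the aromatic nitrogen with another gives a 1.2-fold higher number from compound 3 to compound 4 (0.07 log units; within the scatter) and so shows no real difference. Nitro in place of hydrogen on an aromatic carbon of the phenyl group gives a 1.1-fold higher number from compound 2 to compound 4 (0.02 log units; within the scatter) and adds a second kind of change that also stays within the scatter, so phenyl, 2-chloropyridin-3-yl and 3-nitrophenyl cannot be told apart at this position. No measured evidence on these groups is available to explain this. Still open, on these data alone, is whether an amine or a carboxylic acid on this ring would move the number beyond the scatter.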